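The source may hold more compounds than are shown below. What is called first, only, known or untested is meant among the compounds shown, and "the series" means these compounds.

Measured compounds:
- compound 1, `Cc1c[se]c(N/N=C/c2ccc(Cl)cc2)n1`, gives 49400 nM in a functional assay on DU-145 cells (Homo sapiens) for cytotoxicity, read by XTT assay, with a stated time of 72 h; on this read-out higher numbers stand for weaker inhibition and lower numbers for stronger inhibition.
- compound 2, `Clc1ccc(/C=N/Nc2nc(-c3ccccc3)c[se]2)cc1`, gives 54200 nM in this assay.
- compound 3, `COc1ccc(/C=N/N(C(C)=O)c2nc(C)c[se]2)cc1`, reaches only a limit of the assay, > 74300 nM, in this assay.

Compound 1 and compound 2 share a core and differ in one place: phenyl in place of methyl on an aromatic carbon. The step this made in this assay is a 1.1-fold higher number from compound 1 to compound 2 (0.04 log units; within the scatter), so the two values show no separation that the measurement can resolve.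

Compound 3 carries a different core, and how its core differs from that of compound 1 is not broken down here. Its value in this assay is a limit and not a number, as stated by the limit of > 74300 nM in this assay, at which 1 of the 3 values shown sits.

Compound 4, `COc1ccc(/C=N/N(C(C)=O)c2nc(-c3ccccc3)c[se]2)cc1`, is not yet measured. It stands to compound 3 as compound 2 stands to compound 1: phenyl in place of methyl on an aromatic carbon. The place of the change is described in the same words for both pairs, so this is the same change made on a second core.

Since the earlier instance of this change, compound 1 to compound 2, gave a 1.1-fold higher number from compound 1 to compound 2 (0.04 log units; within the scatter), a step of similar small size is expected from compound 3 to compound 4, namely a step that the limit leaves unreadable from compound 3 to compound 4 in this assay. Because compound 3 is already at the limit (the limit of > 74300 nM in this assay, at which 1 of the 3 values shown sits), compound 4 is expected to sit near or beyond that limit as well. The estimate for compound 4 in this assay is 85000 nM, with a range from 40000 nM to 200000 nM.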

Compound 4, half-maximal inhibitory concentration: > 62700 nM
Compound 4: no number, only a limit; the forecaster's own chance of this, stated with the estimate: 70%; the middle value does not contradict the limit.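

In this assay compound 3 gives only a limit of the assay, > 74300 nM, and not a number. Compound 4 likewise gives only a limit, > 62700 nM, so no step can be read between compound 3 and compound 4. The compounds shown leave open whether phenyl in place of methyl on an aromatic carbon changes the value at all on the core of compound 3.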